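This account rests on a few compounds, and the source may have more. Where it says the series, first, only, none or still open, it means among the compounds named here.

Measured so far in a functional assay on MGC-803 cells (Homo sapiens) for inhibition, read by MTT assay, with a stated time of 72 h; a higher number here means a weaker inhibitor, a lower number a stronger inhibitor:
Compound 1, `CC(C)c1ccc(-c2nc(SCc3cn(CC(=O)NC(=O)Nc4ccccn4)nn3)nc(Nc3ccc(Cl)cc3)c2C#N)cc1`: a limit of the assay, > 64000 nM.
Compound 2, `Cc1ccc(Nc2nc(SCc3cn(CC(=O)NC(=O)Nc4ccccn4)nn3)nc(-c3ccc(C(C)C)cc3)c2C#N)cc1`: 3360 nM.

Among the measured compounds shown here, compound 2 holds the only actual number in this assay; the other value is the limit of > 64000 nM in this assay, at which 1 of the 2 values shown sits, so nothing can be said about where compound 2 stands among several numbers. For the measured compounds named here, the single measured step, an at least 19-fold lower number from compound 1 to compound 2 (1.27 log units; beyond the scatter), shows that the group on the nitrogen attached to the shared core can change the result strongly, but that step exchanged one substituent for another rather than moving it.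

Compound 3, `Cc1cccc(Nc2nc(SCc3cn(CC(=O)NC(=O)Nc4ccccn4)nn3)nc(-c3ccc(C(C)C)cc3)c2C#N)c1`, differs from compound 2 only in that difference: 3-methylphenyl in place of 4-methylphenyl on a nitrogen on an aromatic ring. The same methyl stays on the same ring; only its position changes. Going by the values given here, no measured step covers a move of this kind, so the step from compound 1 to compound 2 gives the size such a ring change can reach, not its direction here. The expectation is therefore a step of a 1.5-fold higher number from compound 2 to compound 3 (0.17 log units; within the scatter), not clearly beyond the scatter, with a wide range. Compound 3 is estimated at 5000 nM, between 1500 nM and 20000 nM.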

Compound 3, half-maximal inhibitory concentration: 25300 nM
Estimate against measurement, compound 3: 5.1-fold (0.70 log units) below, and the stated range ends below it.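

In this assay, moving the methyl while keeping the same atoms gives a 7.5-fold higher number from compound 2 to compound 3 (0.88 log units; beyond the scatter), so on this nitrogen the place of the methyl on the ring matters, and not only which group the ring carries. Even so, 3-methylphenyl remains on the stronger side of 4-chlorophenyl, with an at least 2.5-fold lower number from compound 1 to compound 3 (0.40 log units; beyond the scatter). That step can be read only as a minimum, because compound 1 stands at a limit of the assay rather than at a number: the limit of > 64000 nM in this assay, at which 1 of the 3 values shown sits.

The compounds shown leave open whether chloro would respond to the same move as methyl, since 4-chlorophenyl appears here without a 3-chlorophenyl partner, so the two groups are compared directly only at one ring position. They also leave open how a plain phenyl ring with no substituent, or a ring carrying methoxy or an amine in place of the methyl, would compare, and they give no explanation of why the move of the methyl changes the result by as much as it does.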